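The compounds below may be only part of what the source reports. "The series", "measured", "known", "first", "only" and "open" are said of these compounds alone.

Values so far in a functional assay on MIA PaCa-2 cells (Homo sapiens) for inhibition, read by MTT assay (a lower number here means a stronger inhibitor, a higher number a weaker inhibitor), are these:
Compound 1 `O=C(Nc1ccccc1)c1cc2cnc(Nc3ccc(N4CCNCC4)cn3)nc2n1C1CCCC1` gives 2800 nM
Compound 2 `O=C(Nc1ccccc1Cl)c1cc2cnc(Nc3ccc(N4CCNCC4)cn3)nc2n1C1CCCC1` gives 2170 nM
Compound 3 `O=C(Nc1ccccc1C(F)(F)F)c1cc2cnc(Nc3ccc(N4CCNCC4)cn3)nc2n1C1CCCC1` gives 3160 nM

Compound 3 stands within the scatter of both compound 1 and compound 2, so no order can be read among the three. Compound 4 `Cc1ccccc1NC(=O)c1cc2cnc(Nc3ccc(N4CCNCC4)cn3)nc2n1C1CCCC1` differs from compound 3 in one place (methyl in place of trifluoromethyl on an aromatic carbon), with methyl in place of trifluoromethyl on an aromatic carbon, ortho to a large group. For the measured compounds named here, three measured steps bear on this: chloro in place of hydrogen (a 1.3-fold lower number from compound 1 to compound 2 (0.11 log units; within the scatter)), trifluoromethyl in place of hydrogen (a 1.1-fold higher number from compound 1 to compound 3 (0.05 log units; within the scatter)) and trifluoromethyl in place of chloro (a 1.5-fold higher number from compound 2 to compound 3 (0.16 log units; within the scatter)). All lie within the scatter, so no step beyond it is expected in this assay in either direction. The expected step (a 1.2-fold lower number from compound 3 to compound 4 (0.08 log units; within the scatter)) therefore stays within the scatter. Compound 4 is estimated at 2600 nM (expected range 1400 nM to 4800 nM).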

Compound 4, half-maximal inhibitory concentration: 2500 nM
The estimate for compound 4 lay 1.0-fold (0.02 log units) above the measured number, within the range that was stated.
By their numbers in this assay, from the lowest: compounds 2, 4, 1 and 3 (each within the scatter of the next).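

In this assay, methyl joins hydrogen, chloro and trifluoromethyl at this place on the aromatic ring, and all of its steps stay within the scatter (a 1.3-fold lower number from compound 3 to compound 4 (0.10 log units; within the scatter); a 1.2-fold higher number from compound 2 to compound 4 (0.06 log units; within the scatter); a 1.1-fold lower number from compound 1 to compound 4 (0.05 log units; within the scatter)). Across compound 1, compound 2, compound 3 and compound 4, these four groups therefore give no readable order at this position. Nothing shown here speaks to a cause of this flat result.

Going by these compounds, it remains open whether an amine, a carboxylic acid or a longer chain at this place would produce a step beyond the scatter. Also open, on these data alone, is whether any of these groups would do so elsewhere on the ring.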